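The compounds below may be only part of what the source reports. "The series", "measured", "known", "first", "only" and "open" are said of these compounds alone.

Series notes on the shared core. Compound 1 `CCN1CCN(c2c(CO)c(=O)oc3ccccc23)CC1` in a functional assay on A-375 cells (Homo sapiens) for inhibition, read by MTT assay, with a stated time of 24 h (a higher number here means a weaker inhibitor, a lower number a stronger inhibitor), gives only a limit, > 50000 nM. With the limit of > 50000 nM in this assay, at which 1 of the 3 values shown sits, one of the three values shown is thus a limit rather than a number. For the measured compounds named here, compound 3 `COc1ccccc1N1CCN(c2c(CO)c(=O)oc3ccccc23)CC1` gives 20000 nM, and the step of an at least 2.5-fold lower number from compound 1 to compound 3 (0.39 log units; beyond the scatter) is the single measured step. Compound 2 `O=c1oc2ccccc2c(N2CCN(c3cccc(C(F)(F)F)c3)CC2)c1CO` gives 31900 nM, which lies within the usual scatter of the number for compound 3. Compound 4 `O=c1oc2ccccc2c(N2CCN(c3cccc(Cl)c3)CC2)c1CO` differs from compound 2 by chloro in place of trifluoromethyl on an aromatic carbon. Going by the values given here, no measured step touches a substituent on that aryl ring; the one step concerns the group on the amine nitrogen in a ring and gives no direction here. A step within the scatter is therefore expected, a 1.1-fold lower number from compound 2 to compound 4 (0.03 log units; within the scatter). Compound 4 is estimated at 30000 nM, with a range of 12000 nM to 80000 nM.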

Compound 4, half-maximal inhibitory concentration: 40500 nM
The estimate for compound 4 lay 1.4-fold (0.13 log units) below the measured number, within the range that was stated.
By their numbers in this assay, from the lowest: compounds 3, 2 and 4 (each within the scatter of the next, the first and the last beyond it). At a limit, above all of these: compound 1.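

In this assay, chloro in place of trifluoromethyl on an aromatic carbon gives a 1.3-fold higher number from compound 2 to compound 4 (0.10 log units; within the scatter). With the substituent on the amine nitrogen in a ring changed instead, 3-chlorophenyl in place of 2-methoxyphenyl gives a 2.0-fold higher number from compound 3 to compound 4 (0.31 log units; beyond the scatter), a modest step. 3-Chlorophenyl in place of ethyl on an amine nitrogen in a ring gives an at least 1.2-fold lower number from compound 1 to compound 4 (0.09 log units; that floor lies within the scatter). Compound 1 stands at a limit, so that step is only a floor: the limit of > 50000 nM in this assay, at which 1 of the 4 values shown sits.

Open, on these data alone, is whether an amine or a carboxylic acid on that aryl ring moves the number beyond the scatter. Also open, as far as these compounds go, is what a longer chain in place of ethyl on the ring nitrogen would give.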